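The source may hold more compounds than are shown below. What is called first, only, known or untested is meant among the compounds shown, and "the series" means these compounds.

Working notes on the series. Two compounds sharing the same core have been run in a functional assay on MCF7 cells (Homo sapiens) for inhibition, read by sulforhodamine B assay, with a stated time of 48 h (on this read-out lower numbers stand for stronger inhibition of growth and higher numbers for weaker inhibition of growth), so far. Compound 1 `COC(=O)c1sc2cc(-c3ccc(OC)nc3)cnc2c1N` gives a value that is only a limit of this assay, > 37500 nM. Compound 2 `COC(=O)c1sc2cc(-c3ccc(C#N)cc3)cnc2c1N` likewise gives only a limit, > 75000 nM, so no number is known for it. Where compound 2 stands on the numbers shown is therefore open: its result sits at the limit described by the limit of > 75000 nM in this assay, at which 1 of the 2 values shown sits, and the one other result, that of compound 1, sits at the limit described by the limit of > 37500 nM in this assay, at which 1 of the 2 values shown sits. Neither compound shows measurable growth inhibition under these conditions.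

The next compound, compound 3 `COC(=O)c1sc2cc(-c3ccc(N)cc3)cnc2c1N`, keeps the core of compound 2 and differs in one place: amino in place of cyano on an aromatic carbon. Going by the values given here, no step between measured compounds is known for this change. With both measured compounds at limits, the step from compound 2 to compound 3 in this assay is expected to be small, an at least 1.2-fold lower number from compound 2 to compound 3 (0.09 log units; that floor lies within the scatter), and most likely a further limit rather than a number. Compound 3 is expected around 60000 nM, within 15000 nM to 150000 nM.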

Compound 3, concentration for 50% growth inhibition: 108000 nM
Estimate against measurement, compound 3: 1.8-fold (0.26 log units) below; the range from low to high includes it.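

In this assay, going by these compounds alone, compound 2 gives only a limit (> 75000 nM), and no step from compound 2 to compound 3 can be read. The compounds shown leave open whether amino in place of cyano on an aromatic carbon changes growth inhibition at all, and in which direction.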